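This account rests on a few compounds, and the source may have more. Where it says the series, first, only, none or still open, it means among the compounds named here.

Measured in an ADME assay on a cell-free system (plasma, Homo sapiens) for protein binding, read by HPLC:
- compound 1 `COc1ccc(-c2cc(-c3ccc(S(C)(=O)=O)cc3)cnc2N)cn1` 90%
- compound 2 `CS(=O)(=O)c1ccc(-c2cnc(N)c(-c3ccc(CO)nc3)c2)cc1` 45.9%
- compound 3 `CS(=O)(=O)c1ccc(-c2cnc(N)c(-c3ccc(C(F)(F)F)c(F)c3)c2)cc1` 94.8%

Compound 3 at 94.8% lies within the scatter of compound 1 and well beyond it from compound 2.

The change to compound 4 `CS(=O)(=O)c1ccc(-c2cnc(N)c(-c3ccc(C(F)(F)F)cc3)c2)cc1` is hydrogen in place of fluoro on an aromatic carbon, ortho to a trifluoromethyl group (hydrogen in place of fluoro on an aromatic carbon).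

Among the measured compounds shown here, the only measured step (a 5.4-fold higher unbound fraction from compound 1 to compound 2 (0.73 log units; beyond the scatter)) is a different change, hydroxymethyl in place of methoxy, so it bears only loosely. For the measured compounds named here, no measured step covers the loss of fluoro. A step within the scatter is expected, with a slightly higher unbound fraction as the likelier direction (a 1.3-fold higher unbound fraction from compound 3 to compound 4 (0.10 log units; within the scatter)).

For compound 4 the estimate is 93.5% (expected range 90% to 96.5%).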

Compound 4, plasma protein binding: 96.2%
Beside the measured number, compound 4's estimate is 1.7-fold (0.23 log units) (unbound fraction) above it, within the range that was stated.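

In this assay, hydrogen in place of fluoro, ortho to a trifluoromethyl group, gives a 1.4-fold lower unbound fraction from compound 3 to compound 4 (0.14 log units; within the scatter) and stays within the scatter. At this position, with trifluoromethyl kept, the fluoro therefore has no readable effect on the read-out, and compound 3 and compound 4 cannot be told apart. Nothing measured here explains this result. Going by these compounds, what a carboxylic acid or an amine in place of the trifluoromethyl group would give remains open. On these data alone, whether the same swap stays as quiet without trifluoromethyl also remains open.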